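The compounds below may be only part of what the source reports. "The series", "measured", "known", "first", "only" and "open" are said of these compounds alone.

Measured so far:
- compound 1, `O=S(=O)(c1cccc2nonc12)N1CCOc2c(N3CCNCC3)cc(Cl)cc21`, gives 0.501 nM in an assay on HEK293 cells for displacement of a labelled ligand from 5-hydroxytryptamine receptor 6 (Homo sapiens); on this read-out higher numbers stand for weaker inhibition and lower numbers for stronger inhibition
- compound 2, `Cc1cc(N2CCNCC2)c2c(c1)N(S(=O)(=O)c1ccccc1)CCO2`, gives 2.51 nM in this assay
- compound 3, `O=S(=O)(c1ccccc1F)N1CCOc2c(N3CCNCC3)cc(F)cc21`, gives 0.631 nM in this assay

Among these three, compound 3 holds the second highest number. Its value and that of compound 1 lie within the usual scatter of each other, so nothing separates them; the value of compound 2, by contrast, lies beyond the scatter, on the higher side.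

Compound 4, `CC(C)(C)c1cc(N2CCNCC2)c2c(c1)N(S(=O)(=O)c1ccccc1F)CCO2`, is not yet measured. It differs from compound 3 in one place: tert-butyl in place of fluoro on an aromatic carbon. Among the measured compounds shown here, no pair of measured compounds shows this change on its own. For the measured compounds named here, the only measured compound that carries an alkyl group at that place, compound 2, gives 2.51 nM, but it also carries a different sulfonyl group, so the two changes cannot be told apart. In the absence of a clean comparison, the step of a 2.5-fold higher number from compound 3 to compound 4 (0.40 log units; beyond the scatter) is expected to be modest, toward a higher number, near the edge of the scatter. Compound 4 is therefore estimated at 1.6 nM, within a range of 0.4 nM to 6.3 nM.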

Compound 4, inhibition constant: 7.94 nM
Estimate against measurement, compound 4: 5.0-fold (0.70 log units) below; the measured number lies above the stated range.
By their numbers in this assay, from the lowest: compounds 1 and 3 (each within the scatter of the next); then compound 2; then compound 4.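

In this assay, this position now has its first clean comparison, a 13-fold higher number from compound 3 to compound 4 (1.10 log units; beyond the scatter), with the same sulfonyl group on both compounds. The large step, beyond the scatter, shows that the aromatic carbon para to a fused ring and meta to the piperazin-1-yl group is not indifferent to its substituent: tert-butyl, with 4 heavy atoms, gives clearly weaker inhibition than fluoro, with 1. No measurement shown accounts for this step.

The compounds shown leave open how an isopropyl, ethyl or methoxy group, or an amine, would behave on this carbon, and so whether the number rises gradually or abruptly between fluoro and tert-butyl. They also leave open whether the same change would give a step of similar size with another sulfonyl group.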